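The source may hold more compounds than are shown below. What is called first, only, known or untested is meant among the compounds shown, and "the series" means these compounds.

Measured compounds in an assay (Cricetulus griseus) for inhibition of aldehyde dehydrogenase, mitochondrial (Homo sapiens); a higher number here means a weaker inhibitor, a lower number a stronger inhibitor:
- compound 1 `O=C(O)CCCCOc1ccc2c(=O)c(-c3ccc(O)cc3)coc2c1`: 100 nM
- compound 2 `CC(Oc1ccc2c(=O)c(-c3ccc(O)cc3)coc2c1)C(=O)O`: 2500 nM
- compound 3 `NCCCCOc1ccc2c(=O)c(-c3ccc(O)cc3)coc2c1`: 250 nM

Compound 3 stands second of the three: against compound 1 it shows a 2.5-fold higher number from compound 1 to compound 3 (0.40 log units; beyond the scatter), against compound 2 the step is a 10-fold lower number from compound 2 to compound 3 (1.00 log units; beyond the scatter). Compound 4 `O=C(O)COc1ccc2c(=O)c(-c3ccc(O)cc3)coc2c1` is not yet measured. Its difference from compound 3 is carboxy in place of 3-aminopropyl on a saturated chain carbon bound to an oxygen on an aromatic ring; read over the whole side chain it is 4-aminobutoxy to carboxymethoxy, so compound 4 carries the acid of compound 1 on a shorter chain.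

Going by the values given here, two measured steps bear on this. Exchanging amino for carboxy at the chain end, a 2.5-fold higher number from compound 1 to compound 3 (0.40 log units; beyond the scatter), was modest and favours the acid. Taking the acid onto a shorter chain, a 25-fold higher number from compound 1 to compound 2 (1.40 log units; beyond the scatter), was large and unfavourable. Compound 4 combines the favourable end group with a chain shorter still, so the second effect is expected to dominate. For compound 4 a step of a 12-fold higher number from compound 3 to compound 4 (1.08 log units; beyond the scatter) is therefore expected in this assay, landing near compound 2 or weaker. The estimate for compound 4 is 3000 nM, within 800 nM to 12000 nM.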

Compound 4, half-maximal inhibitory concentration: 1200 nM
Compound 4: middle estimate off by 2.5-fold (0.40 log units), on the high side, and the stated range covers the measured number.
By their numbers in this assay, from the lowest: compound 1; then compound 3; then compound 4; then compound 2.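

In this assay, the carboxymethyl side chain separates chain length from the methyl branch of compound 2: shortening the acid chain alone is a large step (a 12-fold higher number from compound 1 to compound 4 (1.08 log units; beyond the scatter)), while hydrogen in place of methyl gives only a modest one (a 2.1-fold lower number from compound 2 to compound 4 (0.32 log units; beyond the scatter)). Most of the loss on going from 4-carboxybutyl to 1-carboxyethyl therefore goes with the shorter chain, not the methyl. The acid on the shortest chain also falls behind the amine on the long chain (a 4.8-fold higher number from compound 3 to compound 4 (0.68 log units; beyond the scatter)), so the edge of acid over amine at the longer length does not offset the shortening.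

Open, from the compounds shown here alone, is how the numbers run at lengths between carboxymethyl and 4-carboxybutyl, such as 3-carboxypropyl, and whether an amine on a short chain, such as 2-aminoethyl, tracks the acids. Nothing measured here explains these differences.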